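The compounds below may be only part of what the source reports. "The series", "measured", "known", "first", "only" and "open" are said of these compounds alone.

Compound 1 `O=C(O)Cc1ccc(C=C2CCN(C(=O)C(C3CCCCC3)C3CCCCC3)CC2)cc1` is the stronger of the two measured compounds in an assay on isolated protein for inhibition of 3-oxo-5-alpha-steroid 4-dehydrogenase 2 (Homo sapiens) (a lower number here means a stronger inhibitor, a higher number a weaker inhibitor), where compound 1 gives 6 nM. Compound 2 `O=C(O)c1ccc(C=C2CCN(C(=O)CC(c3ccccc3)c3ccccc3)CC2)cc1` gives 1100 nM in this assay, a gap well beyond the scatter, though compound 2 differs from compound 1 in more than one place. Compound 3 `O=C(O)c1ccc(C=C2CCN(C(=O)C(C3CCCCC3)C3CCCCC3)CC2)c(F)c1` keeps the amide of compound 1 and changes the acid-bearing ring: 4-carboxy-2-fluorophenyl in place of 4-(carboxymethyl)phenyl on a double-bonded chain carbon bound to a double-bonded ring carbon. Among the compounds with values here, no single-point step of this kind has been measured, so the expected step of a 5.0-fold higher number from compound 1 to compound 3 (0.70 log units; beyond the scatter) is a moderate weakening, beyond the scatter but far short of the gap to compound 2. Compound 3 is therefore expected to give 30 nM in this assay, within 6 nM to 200 nM.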

Compound 3, half-maximal inhibitory concentration: 11 nM
For compound 3 the middle estimate is 2.7-fold (0.44 log units) above the measured one; low and high end bracket the measured number.
By their numbers in this assay, from the lowest: compounds 1 and 3 (each within the scatter of the next); then compound 2.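

In this assay, the group on a double-bonded chain carbon bound to a double-bonded ring carbon can be changed from 4-(carboxymethyl)phenyl to 4-carboxy-2-fluorophenyl with a 1.8-fold higher number from compound 1 to compound 3 (0.26 log units; within the scatter), so with this amide, this position accepts either group. The change alters two features at once, the link to the carboxylic acid and the fluorine, and this single step cannot separate them. Nothing available accounts for the result. The compounds shown leave open what each feature contributes alone. They also leave open whether a chlorine in place of the fluorine, or a tetrazole in place of the carboxylic acid, would give a similar number.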